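Adding a Nitro Group to Compound 3

The compounds below may be only part of what the source reports. "The series", "measured", "known", "first", "only" and "open" are said of these compounds alone.

In a functional assay on HT-1080 cells (Homo sapiens) for antiproliferative activity, read by MTT assay, with a stated time of 72 h (on this read-out higher numbers stand for weaker inhibition and lower numbers for stronger inhibition), compound 3 `CCOC(=O)c1cc(-c2ccc(OC)cc2)c(-c2cc(OC)c(OC)c(OC)c2)s1` gives 7630 nM and compound 1 `COc1ccc(-c2sc(C(=O)O)cc2-c2cc(OC)c(OC)c(OC)c2)cc1O` gives 7510 nM, two values within the usual scatter of each other. Compound 2 `COc1cc(-c2ccsc2-c2cccc(Br)c2)cc(OC)c1OC` reaches only a limit of the assay, > 100000 nM.

Compound 4 `CCOC(=O)c1cc(-c2ccc(OC)c([N+](=O)[O-])c2)c(-c2cc(OC)c(OC)c(OC)c2)s1` is compound 3 with nitro in place of hydrogen on an aromatic carbon, so 4-methoxyphenyl becomes 4-methoxy-3-nitrophenyl (nitro in place of hydrogen on an aromatic carbon). Among the measured compounds shown here, no measured pair shows this change, so the forecast is cautious: in this assay, a small move toward stronger inhibition is expected, perhaps none beyond the scatter. The expected step is a 1.5-fold lower number from compound 3 to compound 4 (0.18 log units; within the scatter). Compound 4 is estimated at 5000 nM, with an expected range from 800 nM to 30000 nM.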

Compound 4, half-maximal inhibitory concentration: 26100 nM
For compound 4 the middle estimate is 5.2-fold (0.72 log units) below the measured one; low and high end bracket the measured number.
By their numbers in this assay, from the lowest: compounds 1 and 3 (each within the scatter of the next); then compound 4. At a limit, above all of these: compound 2.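

Among the compounds shown here, this is the only measured change at this aromatic carbon, ortho to a methoxy group, and in this assay nitro there weakens inhibition, with a 3.4-fold higher number from compound 3 to compound 4 (0.53 log units; beyond the scatter). The step is modest, but it shows that this position does not accept every group without a change in the read-out. Nothing in the data at hand accounts for the rise. A single group cannot show whether the loss belongs to nitro itself or to any addition at this carbon. An amine or a fluorine atom in the same place would help to tell these two readings apart.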